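Quinoxalinone hydrazides against flavin amine oxidase B

The source may report more compounds than this note shows. Statements on the series, on what has been measured and on what is new or still open speak of the compounds shown alone.

Two compounds carry a benzyl-substituted quinoxaline core. Compound 1 `O=C(NNc1nc2ccccc2nc1Cc1ccccc1)c1ccc(O)cc1` is a hydrazine linked to a hydroxybenzoyl group; compound 2 `Cc1ccc(C(=O)NNC(=O)Cn2c(=O)c(Cc3ccccc3)nc3ccccc32)cc1` is a diacylhydrazide bearing a 4-methylbenzoyl group. In an assay for inhibition of Amine oxidase [flavin-containing] B (Bos taurus), read by fluorescence, with a stated time of 60 min (on this read-out lower numbers stand for stronger inhibition and higher numbers for weaker inhibition), compound 1 gives 940000 nM, and in this assay compound 2 gives 680000 nM. The two numbers sit within the scatter of each other, so compound 2 cannot be set apart from compound 1; both show only weak inhibition. Compound 3 `O=C(Cn1c(=O)c(Cc2ccccc2)nc2ccccc21)N/N=C/c1ccc(Br)cc1` is not yet measured. It differs from compound 2 by a group of 9 heavy atoms (7 carbon, 1 nitrogen, 1 bromine; one six-membered aromatic ring of carbon only) in place of a group of 10 heavy atoms (8 carbon, 1 nitrogen, 1 oxygen; one six-membered aromatic ring of carbon only), on an amide-type nitrogen, the hydrazide becoming a hydrazone. Within the data shown here, no measured pair in this set reports such a step, so the direction rests on the weak level of the two measured values. A change from compound 2 to compound 3 of a 1.5-fold lower number from compound 2 to compound 3 (0.18 log units; within the scatter) is expected, probably not beyond the scatter. Compound 3 is estimated at 450000 nM, with a range from 120000 nM to 1500000 nM.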

Compound 3, half-maximal inhibitory concentration: 26000 nM
Compound 3: middle estimate off by 17-fold (1.24 log units), on the high side; measured number outside the range, below it.
By their numbers in this assay, from the lowest: compound 3; then compounds 2 and 1 (each within the scatter of the next).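

Among these compounds, on the amide-type nitrogen whose other neighbour is the carbonyl carbon, the group matters strongly in this assay: replacing ((4-methylphenyl)carbonyl)amino with the bromine-bearing hydrazone group gives a 26-fold lower number from compound 2 to compound 3 (1.42 log units; beyond the scatter) and is the only readable step in the set. The change turns the hydrazide into a hydrazone and removes the hydrogen-bond donor counted in the leaving group, while a six-membered aromatic ring of carbon only stands on both sides. Nothing measured independently bears on why the number falls.

The step alters the linker, the carbonyl and the ring substituent together, and the compounds shown do not separate these changes. A hydrazone carrying a methyl group or a chlorine atom in place of the bromine would show whether the bromine or the hydrazone linkage accounts for the step.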